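A few compounds are considered here, and "the series" means these few. Any claim that something is new, unique, unknown or untested is made for them only; others in the source may bear on it.

Measured so far in a physicochemical assay for solubility, at pH 7.4 (on this read-out higher numbers stand for higher solubility and lower numbers for lower solubility), for three compounds:
- compound 1 `CC(=O)c1ccc(NC(=O)Nc2cc(C)nc3ccccc23)cc1` gives 3800 nM
- compound 2 `Cc1cc(NC(=O)Nc2cccc(C(N)=O)c2)c2ccccc2n1` gives 100 nM
- compound 3 `Cc1cc(NC(=O)Nc2cc(F)cc(F)c2)c2ccccc2n1` gives 300 nM

Compound 2 stands lowest of the three numbers, and its gaps to compound 3 and to compound 1 both lie beyond the scatter. Next in view is compound 4 `Cc1cc(NC(=O)Nc2cccc(C(C)(C)C)c2)c2ccccc2n1`, which has not yet been measured. It carries tert-butyl in place of carbamoyl on an aromatic carbon, meta to a large group (tert-butyl in place of carbamoyl on an aromatic carbon). For the measured compounds named here, no two measured compounds differ in one place only, so no measured step speaks directly to this change. Going by the values given here, the only guide is a weak one, since these compounds also differ elsewhere: compound 2 with carbamoyl at 100 nM sits under the two measured compounds without it, compound 3 at 300 nM and compound 1 at 3800 nM in the same read-out. A rise beyond the scatter is therefore expected in this assay, landing nearer compound 3 than compound 1. The expected step is a 3.0-fold higher number from compound 2 to compound 4 (0.48 log units; beyond the scatter) as a rough estimate. Compound 4 is estimated at 300 nM, with an expected range from 80 nM to 1500 nM on this read-out.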

Compound 4, solubility: 34700 nM
Beside the measured number, compound 4's estimate is 120-fold (2.06 log units) below it; the whole stated range lies below it.
By their numbers in this assay, from the lowest: compound 2; then compound 3; then compound 1; then compound 4.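

This pair gives the series its first comparison that differs in one place only: on an aromatic carbon of a six-membered aromatic ring of carbon only, meta to a large group, tert-butyl in place of carbamoyl brings a 350-fold higher number from compound 2 to compound 4 (2.54 log units; beyond the scatter) in this assay. The earlier compounds shown here differed in more than one place and could not isolate this change; the step now shows that this single exchange is enough to give a large rise, beyond the scatter, with no ring and no net charge on either side and the carbamoyl's hydrogen-bond donor and acceptor gone. The compounds shown offer nothing that explains the size of this step.

One pair cannot separate what follows from losing carbamoyl from what follows from adding tert-butyl, nor show whether the same exchange would give a similar step elsewhere on the ring or on another core. Also open, from the compounds shown here alone, is where a methyl group, an amine or a carboxylic acid at this same place would fall in this assay relative to the carbamoyl and tert-butyl compounds.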